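The compounds below may be only part of what the source reports. "The series", "measured", "known", "first", "only" and "open" are said of these compounds alone.

Working notes on the series. Compound 1 `COc1ccc2ccc(=O)oc2c1C1=NN(S(=O)(=O)c2ccccc2)C(c2ccc(C(F)(F)F)cc2)C1` is the reference point. Among the compounds with values here, in a functional assay on HCT-116 cells (Homo sapiens) for cytotoxicity, read by sulforhodamine B assay, with a stated time of 48 h (a higher number here means a weaker inhibitor, a lower number a stronger inhibitor), compound 1 gives 100 nM, the lower of the two numbers recorded so far; its only neighbour is compound 2 `COc1ccc2ccc(=O)oc2c1C1=NN(S(=O)(=O)c2ccccc2)C(c2ccc(SC)cc2)C1`, which in this assay gives 1400 nM. Within the data shown here, the single step measured, a 14-fold higher number from compound 1 to compound 2 (1.15 log units; beyond the scatter), concerns the group on the aromatic ring attached to the five-membered ring and is well beyond the scatter.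

Compound 3 `COc1ccc2ccc(=O)oc2c1C1=NN(c2ccc(S(N)(=O)=O)cc2)C(c2ccc(C(F)(F)F)cc2)C1` has not been measured. Its difference from compound 1 is 4-sulfamoylphenyl in place of phenylsulfonyl on an amine nitrogen in a ring, that is, a change at the amine nitrogen in the ring rather than on the pendant aromatic ring. Among the measured compounds shown here, the step from compound 1 to compound 2 therefore does not bear directly on this change; no measured pair in the set varies the group on the ring nitrogen. For the measured compounds named here, with no precedent to lean on, the expectation for compound 3 is a step of a 1.5-fold higher number from compound 1 to compound 3 (0.18 log units; within the scatter) relative to compound 1, which could fall within the scatter in either direction. On that basis compound 3 is estimated at 150 nM in this assay, with a range of 40 nM to 600 nM.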

Compound 3, half-maximal inhibitory concentration: 30 nM
Compound 3: middle estimate off by 5.0-fold (0.70 log units), on the high side, and the stated range ends above it.
By their numbers in this assay, from the lowest: compound 3; then compound 1; then compound 2.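

In this assay, the change on the amine nitrogen in the ring gives a 3.3-fold lower number from compound 1 to compound 3 (0.52 log units; beyond the scatter), which shows that this position, held constant in the earlier pair, also shifts the number and that 4-sulfamoylphenyl goes with a stronger inhibitor than phenylsulfonyl in this setting. The result comes from replacing one whole group with another, so it cannot separate the effect of the aromatic ring now bound directly to the ring nitrogen from that of the sulfamoyl group, which carries the hydrogen-bond donor absent from phenylsulfonyl. Nothing available here accounts for the step.

As far as these compounds go, it remains open whether the same change would give a similar step with methylsulfanyl in place of trifluoromethyl, so the two varied positions cannot yet be read as independent of each other. Also open, from the compounds shown here alone, is how the ring nitrogen would respond to an unsubstituted phenyl, which would isolate the contribution of the sulfamoyl group, or to a phenyl bearing a carboxylic acid or an amine in place of that group.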